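The source may report more compounds than this note shows. Statements on the series, on what has been measured and on what is new or still open speak of the compounds shown alone.

Measured so far:
compound 1 `COc1cc(F)c(NC(=O)c2ncccn2)cc1Nc1nccc(-c2cn(C)c3ccccc23)n1` — 8400 nM
compound 2 `COc1cc(N(C)CCN(C)C)c(NC(=O)c2ccncc2OC)cc1Nc1nccc(-c2cn(C)c3ccccc23)n1` — 2690 nM
compound 3 `COc1cc(N(C)CCN(C)C)c(NC(=O)c2ccncn2)cc1Nc1nccc(-c2cn(C)c3ccccc23)n1` — 2530 nM

All three numbers come from a functional assay on A549 cells (Homo sapiens) for antiproliferative activity, read by MTT assay, with a stated time of 72 h; a lower number here means a stronger inhibitor, a higher number a weaker inhibitor. Compound 3 gives the lowest value of the three, but its gap to compound 2 is within the scatter, so the two cannot be ordered; only compound 1, the analogue that carries a fluorine in place of the amine side chain and a pyrimidin-2-yl on the carbonyl carbon, sits clearly higher.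

The unmeasured compound 4 `COc1cc(N(C)CCN(C)C)c(NC(=O)c2ncccn2)cc1Nc1nccc(-c2cn(C)c3ccccc23)n1` differs from compound 3 in one place: pyrimidin-2-yl in place of pyrimidin-4-yl on a carbonyl carbon. Among the compounds with values here, the one directly comparable step is a 1.1-fold lower number from compound 2 to compound 3 (0.03 log units; within the scatter), a swap of the aryl group on the same carbonyl carbon that changed nothing beyond the scatter. Compound 1 also carries the pyrimidin-2-yl amide, yet it differs from compound 4 at a second position as well, so its value cannot be read as a step for the present change. The expectation is therefore a small step, a 1.2-fold lower number from compound 3 to compound 4 (0.06 log units; within the scatter), with no clear direction beyond the scatter.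

Compound 4 is estimated at 2200 nM in this assay, with a range of 800 nM to 6000 nM.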

Compound 4, half-maximal inhibitory concentration: 2490 nM
Beside the measured number, compound 4's estimate is 1.1-fold (0.05 log units) below it, and the stated range covers the measured number.
By their numbers in this assay, from the lowest: compounds 4, 3 and 2 (each within the scatter of the next); then compound 1.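

In this assay, pyrimidin-2-yl in place of pyrimidin-4-yl on a carbonyl carbon gives a 1.0-fold lower number from compound 3 to compound 4 (0.01 log units; within the scatter) and pyrimidin-2-yl in place of 3-methoxypyridin-4-yl gives a 1.1-fold lower number from compound 2 to compound 4 (0.03 log units; within the scatter), so the three aromatic groups seen on this carbonyl carbon cannot be told apart in this assay, even for the two pyrimidinyl isomers. Within the data shown here, the pyrimidin-2-yl amide also allows the first single-place reading at the aromatic carbon, where (2-(dimethylamino)ethyl)(methyl)amino in place of fluoro gives a 3.4-fold lower number from compound 1 to compound 4 (0.53 log units; beyond the scatter), a modest step and the only one here beyond the scatter. No measurement here gives a reason for either result.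

The compounds shown leave open how a morpholine or a shorter amine chain on the aromatic carbon would compare with (2-(dimethylamino)ethyl)(methyl)amino, since fluoro is the only other group seen there. They also leave open whether the flat reading on the carbonyl carbon extends to a phenyl group or a saturated ring such as piperidine, and whether it holds when fluoro rather than the amine side chain sits on the aromatic carbon.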